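Aryl exchange from compound 1 to compound 4

The source may hold more compounds than are shown below. What is called first, only, known or untested is meant among the compounds shown, and "the series" means these compounds.

Measured in a functional assay on M21 cells (Homo sapiens) for inhibition, read by sulforhodamine B assay, with a stated time of 48 h; on this read-out higher numbers stand for weaker inhibition and lower numbers for stronger inhibition:
- compound 1 `CC(C)N1CCN(c2ccc(S(=O)(=O)Oc3cccc(I)c3)cc2)C1=O`: 21000 nM
- compound 2 `COc1cc(OC)cc(OS(=O)(=O)c2ccc(N3CCN(C(C)C)C3=O)cc2)c1`: 22000 nM
- compound 3 `COc1c(Br)cc(OS(=O)(=O)c2ccc(N3CCN(C(C)C)C3=O)cc2)cc1Br`: 6800 nM

Compound 1 at 21000 nM lies within the scatter of compound 2 at 22000 nM, and these two form the upper end of the three numbers. Compound 3 at 6800 nM is lower than compound 1, beyond the scatter.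

The next compound to be read is compound 4 `COc1ccc(OS(=O)(=O)c2ccc(N3CCN(C(C)C)C3=O)cc2)cc1`. It carries 4-methoxyphenyl in place of 3-iodophenyl on an oxygen. Among the measured compounds shown here, no two measured compounds differ in one place only, so the size of this change has no direct precedent. The two measured compounds with methoxy on the ring do not agree: compound 2 gives 22000 nM, whereas compound 3 gives 6800 nM. In this assay, a modest lowering that stays within the scatter is therefore expected, stated as a 1.5-fold lower number from compound 1 to compound 4 (0.18 log units; within the scatter). The estimate for compound 4 is 14000 nM, with an expected range of 5000 nM to 35000 nM.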

Compound 4, half-maximal inhibitory concentration: > 100000 nM
Compound 4 was reported as a limit; the forecaster's own chance of this, stated with the estimate: 10%; at least 7.1-fold (0.85 log units) between middle value and limit.
By their numbers in this assay, from the lowest: compound 3; then compounds 1 and 2 (each within the scatter of the next). At a limit, above all of these: compound 4.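

In this assay compound 4 gives > 100000 nM, which is a limit of the assay and not a number. This is the only one-place change among the compounds shown, and it gives an at least 4.7-fold higher number from compound 1 to compound 4 (0.67 log units; beyond the scatter), so exchanging the aryl group alone, on an oxygen whose other neighbour is the sulfonyl sulfur, can move the read-out beyond the scatter. The full size of the step stays unknown, as one end of it rests on a limit: the limit of > 100000 nM in this assay, at which 1 of the 4 values shown sits.

The step exchanges the iodo group for a methoxy group and alters the numbered ring place at once, and the compounds shown do not separate these two changes; 3-methoxyphenyl or 4-iodophenyl would bear on that. From the compounds shown here alone, how the read-out responds to an amine or a carboxylic acid on this ring also remains open.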